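The source may report more compounds than this note shows. Statements on the series, on what has been measured and on what is new or still open speak of the compounds shown alone.

Compound 1 `Oc1nnc(-c2ccccc2)c2cncn12` was tested in a functional assay for inhibition, with Homo sapiens as the target; on this read-out higher numbers stand for weaker inhibition and lower numbers for stronger inhibition. In this assay compound 1 gives 19000 nM. Compound 3 `CCCc1nc(C)c2c(-c3ccccc3)nnc(O)n12` is built on another core; the difference between the two cores is not broken down here. In this assay compound 3 gives > 48000 nM, which is a limit of the assay and not a number. Compound 2 `CCCc1nc(C)c2c(-c3ccccc3)nnc(SC)n12` is compound 3 with methylsulfanyl in place of hydroxy on an aromatic carbon. In this assay compound 2 gives > 48000 nM, again a limit rather than a number. The step that the two limits leave unreadable from compound 3 to compound 2 therefore cannot be read, because both values rest on (the limit of > 48000 nM in this assay, at which 2 of the 3 values shown sit).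

Compound 4 `CSc1nnc(-c2ccccc2)c2cncn12` has not been measured yet; it is compound 1 with methylsulfanyl in place of hydroxy on an aromatic carbon. Among the measured compounds shown here, this is the same kind of change as the one from compound 3 to compound 2, but not the same change: in compound 1 the carbon that carries it is para to a group of 6 heavy atoms, whereas in compound 3 it is para to a phenyl group (6 heavy atoms). For the measured compounds named here, the measured pair gives no readable size for this change, so the only anchor is the value of compound 1. Starting from compound 1 with 19000 nM, the step to compound 4 is expected to be a 1.3-fold higher number from compound 1 to compound 4 (0.12 log units; within the scatter). Compound 4 is thus estimated at 25000 nM, most likely between 8000 nM and 80000 nM.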

Compound 4, half-maximal inhibitory concentration: > 48000 nM
Compound 4 was reported as a limit; the forecaster's own chance of this, stated with the estimate: 35%; at least 1.9-fold (0.28 log units) between middle value and limit.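

On the core of compound 1, in this assay, methylsulfanyl in place of hydroxy on an aromatic carbon gives an at least 2.5-fold higher number from compound 1 to compound 4 (0.40 log units; beyond the scatter), so on this core the change shifts the read-out towards weaker inhibition by more than the usual scatter. Compound 4 gives > 48000 nM, which is a limit of the assay and not a number, so the true size of the step may be larger than the one printed. Whether the change acts alike on both cores stays unanswered, as the step from compound 3 to compound 2 cannot be read, and the result on the core of compound 1 neither confirms nor contradicts a shared effect, because so many of the values rest on a limit: the limit of > 48000 nM in this assay, at which 3 of the 4 values shown sit.

The compounds shown leave open how an amine or a methoxy group would read on this same aromatic carbon of the core of compound 1, where compound 1 gives 19000 nM, the only number available for comparison. They also leave open whether an amine on the core of compound 3 would give a measurable number at all.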